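Swapping the Aryl Group on a Shared Core

The source may report more compounds than this note shows. Statements on the series, on what has been measured and on what is new or still open speak of the compounds shown alone.

Three measured compounds share one core and differ in the aromatic group on a saturated ring carbon and in the ester. Compound 1 `CCOC(=O)/C(=C/c1ccccc1)CN1C(=O)[C@@H](OC)[C@H]1c1ccc(Cl)cc1` in a functional assay on MDA-MB-231 cells (Homo sapiens) for antiproliferative activity, read by MTT assay, with a stated time of 48 h (on this read-out higher numbers stand for weaker inhibition and lower numbers for stronger inhibition), gives 11100 nM. Among the compounds with values here, compound 2 `CCOC(=O)/C(=C/c1ccccc1)CN1C(=O)[C@@H](OC)[C@H]1c1ccc(F)cc1` in this assay gives 14000 nM, and the step of a 1.3-fold higher number from compound 1 to compound 2 (0.10 log units; within the scatter) is the only single-point change among the measured pairs. Compound 3 `COC(=O)/C(=C/c1ccccc1)CN1C(=O)[C@@H](OC)[C@H]1c1cccc(C(F)(F)F)c1` in this assay gives 18200 nM, the highest of the three numbers, though its gaps to compound 2 and to compound 1 both fall within the scatter, so no ordering among the three can be claimed. The unmeasured compound 4 `COC(=O)/C(=C/c1ccccc1)CN1C(=O)[C@@H](OC)[C@H]1c1ccc(Cl)cc1Cl` carries 2,4-dichlorophenyl in place of 3-(trifluoromethyl)phenyl on a saturated ring carbon. Within the data shown here, the one measured step that bears on a halogen change on this aromatic group, a 1.3-fold higher number from compound 1 to compound 2 (0.10 log units; within the scatter), stayed within the scatter, and all three numbers sit close together. Compound 4 is therefore expected to land near its neighbours, with an estimated 12500 nM between 5000 nM and 32000 nM, an expected step of a 1.5-fold lower number from compound 3 to compound 4 (0.16 log units; within the scatter) that should not exceed the scatter.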

Compound 4, half-maximal inhibitory concentration: 19000 nM
Compound 4: the middle estimate sits 1.5-fold (0.18 log units) below what was measured, within the range that was stated.
By their numbers in this assay, from the lowest: compounds 1, 2, 3 and 4 (each within the scatter of the next).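

In this assay, the step of a 1.0-fold higher number from compound 3 to compound 4 (0.02 log units; within the scatter) shows that 2,4-dichlorophenyl can stand in place of 3-(trifluoromethyl)phenyl on this saturated ring carbon without a readable change. The earlier step exchanged only one halogen for another, whereas this one replaces the whole substituted aromatic group, and the reading still stays within the scatter. Nothing among the data shown accounts for this tolerance.

From the compounds shown here alone, it remains open whether any group on this ring carbon can move the number beyond the scatter, for instance a phenyl ring carrying an amine or a carboxylic acid. Also open, going by these compounds, is how the methyl and ethyl esters compare when the aromatic group is held the same.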